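From a pyrrole to an imidazole side chain

The source may hold more compounds than are shown below. What is called first, only, known or untested is meant among the compounds shown, and "the series" means these compounds.

Measured so far in a functional assay on A549 cells (Homo sapiens) for antiproliferative activity, read by MTT assay, with a stated time of 48 h; a lower number here means a stronger inhibitor, a higher number a weaker inhibitor
compound 1 `Cn1cc(C2=C(c3nn(CCCn4cccc4)c4ncccc34)C(=O)NC2=O)c2ccccc21` gives > 100000 nM (a limit)
compound 2 `Cn1cc(C2=C(c3nn(CCCN4CCCCC4)c4ncccc34)C(=O)N(c3ccc(Cl)cc3)C2=O)c2ccccc21` gives 28700 nM
compound 3 `Cn1cc(C2=C(c3nn(CCCN4CCCCC4)c4ncccc34)C(=O)N(c3ccccn3)C2=O)c2ccccc21` gives > 100000 nM (a limit)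

On these data alone, compound 1 stands at > 100000 nM in this assay and this is a limit, not a number, so its true value is unknown. The change from compound 1 to compound 4 `Cn1cc(C2=C(c3nn(CCn4ccnc4)c4ncccc34)C(=O)NC2=O)c2ccccc21` lies in the side chain 1H-imidazol-1-yl in place of (1H-pyrrol-1-yl)methyl on a saturated chain carbon, two bonds along the chain from an aromatic nitrogen and reads 1H-imidazol-1-yl in place of (1H-pyrrol-1-yl)methyl on a saturated chain carbon, two bonds along the chain from an aromatic nitrogen. Cut one bond further out, 3-(1H-pyrrol-1-yl)propyl gives way to 2-(1H-imidazol-1-yl)ethyl.

For the measured compounds named here, no measured step touches this side chain. Going by the values given here, the one step available, an at least 3.4-fold higher number from compound 2 to compound 3 (0.54 log units; beyond the scatter), is a change on an amide-type nitrogen in a ring, so it bears on compound 4 only loosely. Among the compounds with values here, compound 2 is the only compound with a true number, and compound 4 lacks its 4-chlorophenyl group. Within the data shown here, the series so far offers the limit of > 100000 nM in this assay, at which 2 of the 3 values shown sit, as its main landmark. The expectation therefore rests on compound 1, whose > 100000 nM is a limit. No clear step is expected, and a small gain is the most that seems likely. The expected step is an at least 1.4-fold lower number from compound 1 to compound 4 (0.15 log units; that floor lies within the scatter) and it remains a rough estimate. Compound 4 is expected at about 70000 nM within an estimated range of 20000 nM to 100000 nM and it may well return only a limit.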

Compound 4, half-maximal inhibitory concentration: > 100000 nM
Compound 4 was reported as a limit; the forecaster's own chance of this, stated with the estimate: 60%; middle value at least 1.4-fold (0.15 log units) away from the limit.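

In this assay compound 4 gives > 100000 nM, which is a limit. For the compounds shown here, compound 1 gives > 100000 nM, also a limit, so no step from it to compound 4 can be read. The compounds shown leave open how far apart the true values of these two compounds lie, and whether exchanging 3-(1H-pyrrol-1-yl)propyl for 2-(1H-imidazol-1-yl)ethyl changes activity at all.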